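The compounds below may be only part of what the source reports. "The series", "measured", "known", "first", "only" and "open" are said of these compounds alone.

In a functional assay on PC-3 cells (Homo sapiens) for antiproliferative activity, read by MTT assay, with a stated time of 96 h (on this read-out higher numbers stand for weaker inhibition of growth and lower numbers for stronger inhibition of growth), compound 1 `Cc1ccnc(Nc2ccc3ccccc3n2)c1` gives 26700 nM. Compound 2 `Clc1ccnc(Nc2ccc3ccccc3n2)c1` differs from compound 1 by chloro in place of methyl on an aromatic carbon. For compound 2 this assay reports only a limit, > 30000 nM. Compound 3 `Cc1ccnc(Nc2ccc3c(Cl)ccc(O)c3n2)c1` is built on a different core; how the two cores differ is not broken down here. In this assay compound 3 gives 10200 nM, which is the lower of the two numbers available and sits beyond the scatter from the value of compound 1.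

Compound 4 `Oc1ccc(Cl)c2ccc(Nc3cc(Cl)ccn3)nc12` has not yet been measured. It differs from compound 3 by chloro in place of methyl on an aromatic carbon. This is the same change as that made from compound 1 to compound 2, the place being the same word for word, and among the compounds shown it occurs twice in all. The first time it gave an at least 1.1-fold higher number from compound 1 to compound 2 (0.05 log units; that floor lies within the scatter), a step whose size can only be bounded by the limit (the limit of > 30000 nM in this assay, at which 1 of the 3 values shown sits).

On that basis compound 4 is expected to give about 18000 nM in this assay, most likely between 9000 nM and 36000 nM. That estimate means the expected step of a 1.8-fold higher number from compound 3 to compound 4 (0.25 log units; within the scatter), and it rests on the earlier step of an at least 1.1-fold higher number from compound 1 to compound 2 (0.05 log units; that floor lies within the scatter), which may itself have been larger than its floor because the limit of > 30000 nM in this assay, at which 1 of the 3 values shown sits, hides the true size. Since compound 3 starts from a lower number than compound 1, there is more room before the limit is reached, yet a result reported only as a limit remains a real possibility.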

Compound 4, concentration for 50% growth inhibition: 25500 nM
The estimate for compound 4 lay 1.4-fold (0.15 log units) below the measured number; measured number inside the range.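

In this assay, chloro in place of methyl on the core of compound 3 gave a 2.5-fold higher number from compound 3 to compound 4 (0.40 log units; beyond the scatter), so on this core the change clearly moved the result towards weaker inhibition of growth. For compound 2, this assay reports only > 30000 nM, which is a limit of the assay and not a number. The two steps therefore point the same way as far as they can be read, which suggests that the direction of the change may carry over between these two cores, but they do not show that its size carries over, and two cores make no rule for the series: the same change on two cores in this assay, an at least 1.1-fold higher number (0.05 log units; that floor lies within the scatter) from compound 1 to compound 2 and a 2.5-fold higher number (0.40 log units; beyond the scatter) from compound 3 to compound 4; the limit leaves it open whether they differ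

The compounds shown leave open whether another group at this place, opposite the ring nitrogen, such as fluoro, methoxy, an amine or a carboxylic acid, would shift the result in the same direction as chloro. They also leave open how much each of the groups that set the core of compound 3 apart from the core of compound 1 contributes, and whether the change would behave in the same way on a third core.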